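This account rests on a few compounds, and the source may have more. Where it says the series, first, only, none or still open, it means among the compounds named here.

Of the compounds shown here, three built on one shared core have been tested in a functional assay on HepG2 cells (Homo sapiens) for cytotoxicity, with a stated time of 72 h; on this read-out higher numbers stand for an effect only at larger amounts of compound and lower numbers for an effect already at smaller amounts. Compound 1 `C=C[C@@](C)(/C=C/c1ccc(O)c(/C=C/C#N)c1)CCC=C(C)C`, with cyano on the double-bonded chain, gives > 52000 nM, which is a limit and not a number. Compound 2 `C=C[C@@](C)(/C=C/c1ccc(O)c(/C=C/c2ccc(F)cc2)c1)CCC=C(C)C`, with 4-fluorophenyl at that place, gives > 52000 nM, again a limit. Compound 3 `C=C[C@@](C)(/C=C/c1ccc(O)c(/C=C/c2ccc(Cl)c(Cl)c2)c1)CCC=C(C)C`, with 3,4-dichlorophenyl there, gives > 52000 nM, also a limit. The whole set thus comes down to the limit of > 52000 nM in this assay, at which 3 of the 3 values shown sit, and compound 3 stands there with the other two.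

Compound 4 `C=C[C@@](C)(/C=C/c1ccc(O)c(/C=C/C=C/c2ccccc2)c1)CCC=C(C)C` has not yet been measured. Its difference from compound 3 is 2-phenylethenyl in place of 3,4-dichlorophenyl on a double-bonded chain carbon bound to a double-bonded chain carbon.

Among the measured compounds shown here, three measured steps bear on this place: a step that the two limits leave unreadable from compound 1 to compound 2, a step that the two limits leave unreadable from compound 1 to compound 3 and a step that the two limits leave unreadable from compound 2 to compound 3. None of them has a readable size, and none of these groups yielded a number. No step beyond the scatter is therefore expected in this assay, and no direction can be drawn from these limits. Another limit is the likeliest report for compound 4. As a value, compound 4 is estimated at 60000 nM, within an expected range of 25000 nM to 120000 nM. The expected change is a step that the limit leaves unreadable from compound 3 to compound 4.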

Compound 4, half-maximal effective concentration: > 52000 nM
Compound 4 gave a limit, no number; the forecaster's own chance of this, stated with the estimate: 80%; the middle value does not contradict the limit.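

No step can be read among compound 1, compound 2, compound 3 and compound 4 in this assay, as each gives only a limit and no number: the limit of > 52000 nM in this assay, at which 4 of the 4 values shown sit.

The compounds shown leave open whether any of these groups on the double-bonded chain carbon differs from another in this assay, and by how much.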